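One Change on the Sulfonyl Sulfur: Compound 2 to Compound 4

The compounds below may be only part of what the source reports. "The series", "measured", "known", "first", "only" and "open" are said of these compounds alone.

Measured compounds:
compound 1, `CC(O)(C(=O)Nc1cccc(S(=O)(=O)c2ccccc2)c1)C(F)(F)F`, gives > 30000 nM, which is a limit of the assay and not a number
compound 2, `CC(O)(C(=O)Nc1ccc(S(=O)(=O)c2cccc(F)c2)cc1)C(F)(F)F`, gives 3400 nM
compound 3, `CC(O)(C(=O)Nc1ccc(C#N)c(Sc2ccccc2)c1)C(F)(F)F`, gives 8300 nM

All three share an amide built on a trifluoromethyl-bearing hydroxy acid and were tested in a functional assay (Cavia porcellus) with sulfonylurea receptors; K-ATP channels (Homo sapiens) as the target; a lower number here means a stronger inhibitor, a higher number a weaker inhibitor. Compound 2 has the lowest of the two real numbers; compound 3 sits higher, and the gap between them is beyond the usual scatter. Compound 1 sits at the limit of > 30000 nM in this assay, at which 1 of the 3 values shown sits, so it gives no number to compare.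

The untested compound 4, `CC(O)(C(=O)Nc1ccc(S(=O)(=O)c2ccccc2C#N)cc1)C(F)(F)F`, differs from compound 2 in one place: 2-cyanophenyl in place of 3-fluorophenyl on a sulfonyl sulfur. Within the data shown here, no measured pair isolates this exchange, and the nitrile of compound 3 sits on the core rather than on the ring attached to the sulfonyl sulfur, so it gives no direct guide. The expected step from compound 2 to compound 4 is therefore small, a 1.2-fold higher number from compound 2 to compound 4 (0.07 log units; within the scatter), with no clear direction beyond the scatter. Compound 4 is accordingly estimated at 4000 nM, between 1500 nM and 12000 nM.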

Compound 4, half-maximal inhibitory concentration: 1100 nM
Estimate against measurement, compound 4: 3.6-fold (0.56 log units) above, outside the stated range (below it).
By their numbers in this assay, from the lowest: compound 4; then compound 2; then compound 3. At a limit, above all of these: compound 1.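

In this assay, 2-cyanophenyl in place of 3-fluorophenyl on a sulfonyl sulfur gives a 3.1-fold lower number from compound 2 to compound 4 (0.49 log units; beyond the scatter) and thus a modest step beyond the scatter. This is the only pair shown that isolates a change at this place, and it shows that the aromatic ring on the sulfonyl sulfur can shift the inhibitory number and that a nitrile-bearing ring is accepted there. The data shown offer no measurement that bears on why this exchange lowers the number.

The fluorine leaves in the same step as the nitrile enters, which leaves open whether the nitrile alone accounts for the change. From the compounds shown here alone, how an amine or a carboxylic acid on this ring would read in this assay also remains open.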